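Ester to Hydroxymethyl on a Three-Membered Ring: Cytotoxicity

A few compounds are considered here, and "the series" means these few. Any claim that something is new, unique, unknown or untested is made for them only; others in the source may bear on it.

Compound 1 `CCOC(=O)[C@]1(C(=O)Nc2ccccc2)C[C@@H]1c1cc(OC)c(OC)c(OC)c1` — in a functional assay on HeLa cells (Homo sapiens) for cytotoxicity, read by MTT assay, with a stated time of 48 h (on this read-out higher numbers stand for weaker inhibition and lower numbers for stronger inhibition), compound 1 gives > 100000 nM, a limit of the assay.
Compound 2 `COc1cc([C@H]2C[C@]2(CO)C(=O)Nc2ccccc2)cc(OC)c1OC` — in this assay compound 2 gives > 100000 nM, also a limit.
Compound 3 `CCOC(=O)[C@@]1(C(=O)NCc2ccc(C)cc2)C[C@@H]1c1cc(OC)c(OC)c(OC)c1` — in this assay compound 3 gives > 100000 nM, again a limit.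

Compound 2 differs from compound 1 by hydroxymethyl in place of ethoxycarbonyl on a saturated ring carbon, and the resulting step is a step that the two limits leave unreadable from compound 1 to compound 2. All three measured values sit at the limit of > 100000 nM in this assay, at which 3 of the 3 values shown sit. Compound 1 and compound 3 carry different amide ends; the difference between the two cores is not broken down here. Compound 4 `COc1cc([C@H]2C[C@@]2(CO)C(=O)NCc2ccc(C)cc2)cc(OC)c1OC` is obtained from compound 3 by hydroxymethyl in place of ethoxycarbonyl on a saturated ring carbon, the same change as between compound 1 and compound 2, at the same place. With the step that the two limits leave unreadable from compound 1 to compound 2 not readable, the expected step is a step that the limit leaves unreadable from compound 3 to compound 4, and compound 4 is expected to return only a limit as well. Compound 4 is estimated at 200000 nM, between 50000 nM and 1000000 nM.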

Compound 4, half-maximal inhibitory concentration: > 100000 nM
Compound 4: no number, only a limit (the forecaster's own chance of this, stated with the estimate: 85%); the middle value lies beyond the limit too.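

In this assay compound 4 gives > 100000 nM as a limit and not a number, and compound 3 is also at a limit, so no step can be read between these two compounds: the limit of > 100000 nM in this assay, at which 4 of the 4 values shown sit.

The compounds shown leave open whether hydroxymethyl in place of ethoxycarbonyl changes cytotoxicity at all.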